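The source may hold more compounds than are shown below. What is called first, only, known or untested is meant among the compounds shown, and "the series" means these compounds.

Of the compounds shown here, three have been measured so far in a physicochemical assay for lipophilicity, at pH 7.4 (a higher number here means a more lipophilic compound, a lower number a more polar compound), on this series. Compound 1 `N#Cc1ccc(O[C@H]2CN(S(=O)(=O)c3ccc(Cl)cc3Cl)C[C@@]2(O)CN)cc1F` gives 4 there, and compound 2 `N#Cc1ccc(O[C@H]2CN(S(=O)(=O)c3ccc(Cl)cc3Cl)C[C@]2(O)CO)cc1F` gives 4.9 on the same scale. Compound 3 `N#Cc1ccc(O[C@H]2CN(S(=O)(=O)c3ccccc3C#N)C[C@@]2(O)CO)cc1F` stands lowest of the three at 3.4 and lies beyond the scatter of repeated measurements from both others, with compound 1 nearest and compound 2 furthest.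

Compound 4 `N#Cc1ccc(O[C@H]2CN(S(=O)(=O)c3ccc(C(F)(F)F)nc3)C[C@@]2(O)CO)cc1F` has not yet been measured. It differs from compound 3 in one place, a sulfonyl sulfur whose other neighbours are a sulfonamide nitrogen in a ring, where 6-(trifluoromethyl)pyridin-3-yl comes in place of 2-cyanophenyl 6-(trifluoromethyl)pyridin-3-yl in place of 2-cyanophenyl on a sulfonyl sulfur and the rest stays the same.

Within the data shown here, no pair of measured compounds differs in a single place, so the expectation rests on the spread of values alone. Compound 3 at 3.4 sits at the bottom of that spread, and compound 2 at 4.9 marks its top, though it differs from compound 3 in more than one place. An upward a number 0.70 log units higher from compound 3 to compound 4 (beyond the scatter) is therefore expected, most likely beyond the scatter. For compound 4 the estimated value is 4.1 with an expected range from 3.6 to 4.6 as the likely span.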

Compound 4, distribution coefficient: 4.2
The estimate for compound 4 lay 0.10 log units below the measured number, and the stated range covers the measured number.
By their numbers in this assay, from the lowest: compound 3; then compounds 1 and 4 (each within the scatter of the next); then compound 2.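

Among these compounds, the replacement gives the first step that can be read at a single position: in this assay, putting 6-(trifluoromethyl)pyridin-3-yl in place of 2-cyanophenyl on a sulfonyl sulfur whose other neighbours are a sulfonamide nitrogen in a ring gives a number 0.80 log units higher from compound 3 to compound 4 (beyond the scatter), with the rest of the structure unchanged. Among the compounds shown here, the position therefore responds measurably in this assay to a change of this group, which the earlier compounds could not show, as none of them formed a pair differing in one place. The entering group has 10 heavy atoms against 8 in the group that leaves, a ring with 1 hetero atom in place of a ring of carbon only, and no triple bond, while each group counts 1 hydrogen-bond acceptor, but no measurement available here ties the step to any one of these differences.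

The compounds shown leave open how a plain phenyl, a pyridin-3-yl without the trifluoromethyl group or a 6-methoxypyridin-3-yl would read on the same sulfonyl sulfur. They also leave open whether the same replacement would give a step of similar size on a compound carrying an aminomethyl group in place of the hydroxymethyl group.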